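Oxolan-3-yl in place of oxan-3-yl in the series

The source may report more compounds than this note shows. Statements on the series, on what has been measured and on what is new or still open speak of the compounds shown alone.

In an ADME assay on MDCKII-LE cells (Canis lupus familiaris) for permeability, read by transwell migration, in the apical to basolateral direction (a higher number here means that the compound crosses the layer faster, a lower number that the compound crosses the layer more slowly), compound 1 `NC(=O)[C@@H](CCC(F)(F)F)N(C[C@H]1CCCCO1)S(=O)(=O)c1ccc(Cl)cc1` gives 13.4 10^-6 cm/s as its value, compound 2 `NC(=O)[C@@H](CCC(F)(F)F)N(C[C@H]1CCCOC1)S(=O)(=O)c1ccc(Cl)cc1` gives 18.2 10^-6 cm/s and compound 3 `NC(=O)[C@@H](CCC(F)(F)F)N(C[C@@H]1CCCOC1)S(=O)(=O)c1ccc(Cl)cc1` gives 18.4 10^-6 cm/s on the same read-out. These three numbers lie within the scatter of one another, so compound 3 holds no separate place among them.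

The next structure is compound 4 `NC(=O)[C@@H](CCC(F)(F)F)N(C[C@@H]1CCOC1)S(=O)(=O)c1ccc(Cl)cc1`, reached from compound 3 by the change oxolan-3-yl in place of oxan-3-yl on a saturated chain carbon bound to a sulfonamide nitrogen in the group on a saturated chain carbon bound to a sulfonamide nitrogen. Within the data shown here, no measured step alters the ring size. The closest evidence is the swap of oxan-2-yl for oxan-3-yl, seen as a 1.4-fold higher number from compound 1 to compound 2 (0.13 log units; within the scatter) and as a 1.4-fold higher number from compound 1 to compound 3 (0.14 log units; within the scatter) in the two measured pairs, both within the scatter. The step of a 1.0-fold higher number from compound 2 to compound 3 (0.00 log units; within the scatter) is also within the scatter, and the fact that compounds 2 and 3 differ only in the configuration as drawn is what separates that pair.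

With every measured step this small, no step beyond the scatter is expected in this assay and no direction is favoured. The expected step is a 1.1-fold lower number from compound 3 to compound 4 (0.03 log units; within the scatter) and it stays within the scatter. The estimated value for compound 4 is 17 10^-6 cm/s with 10 10^-6 cm/s to 28 10^-6 cm/s as the expected range.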

Compound 4, apparent permeability: 20.5 10^-6 cm/s
Compound 4: the middle estimate sits 1.2-fold (0.08 log units) below what was measured; measured number inside the range.
By their numbers in this assay, from the lowest: compounds 1, 2, 3 and 4 (each within the scatter of the next).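

In this assay the series now includes a change of ring size, and the step for oxolan-3-yl in place of oxan-3-yl on a saturated chain carbon bound to a sulfonamide nitrogen, a 1.1-fold higher number from compound 3 to compound 4 (0.05 log units; within the scatter), shows that this position tolerates the five-membered ring without a measurable shift. The comparisons a 1.1-fold higher number from compound 2 to compound 4 (0.05 log units; within the scatter) and a 1.5-fold higher number from compound 1 to compound 4 (0.18 log units; within the scatter) point the same way, so all four compounds remain within the scatter of one another in this assay despite differing in ring size, in the ring attachment named oxan-2-yl or oxan-3-yl, and in drawn configuration. The information available on these compounds does not bear on what lies behind the result for the oxolan-3-yl group.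

From the compounds shown here alone, it remains open whether this flat reading holds when the ether ring at this place gives way to an amine, a carboxylic acid or a longer chain. The compounds shown also leave open how oxolan-2-yl and the opposite drawn configuration of oxolan-3-yl would read in this assay on the same core.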